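Aryl for alkyl on the amino nitrogen of compound 3

This account rests on a few compounds, and the source may have more. Where it says the series, first, only, none or still open, it means among the compounds named here.

Of the compounds shown here, three have been tested in a functional assay on the whole organism (strain Wistar) for inhibition, with Rattus norvegicus as the target, read by paw edema, with a stated time of 4 h, at a dose of 10 mg/kg by the oral route; a lower number here means less inhibition, a higher number more inhibition at the dose given (going by the name of the read-out). Compound 1 `Clc1ccc(COc2nnc(COc3ccc(-c4ccccc4)cc3)o2)c(Cl)c1` gives 29.5% in this assay. Compound 2 `CCCCNc1nnc(COc2ccc(-c3ccccc3)cc2)o1` gives 15.9%. Compound 3 `CCCCNc1nnc(COc2ccc(-c3ccccc3)cc2)s1` gives 27.3% and so stands second highest of the three numbers; its nearest neighbour is compound 1, higher by a margin that lies within the usual scatter, while compound 2 sits furthest away, lower by a margin beyond the scatter. No pair among these three differs in only one place, so no single structural step can be read from the measured values.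

Compound 4 `Fc1ccc(Nc2nnc(COc3ccc(-c4ccccc4)cc3)s2)cc1` has not yet been measured. It differs from compound 3 in one place: 4-fluorophenyl in place of butyl on a nitrogen on an aromatic ring. Nothing in the measured set isolates this change, so the expectation rests on the spread of the numbers seen so far. The step from compound 3 to compound 4 in this assay is estimated at a number 2.7 percentage points higher from compound 3 to compound 4 (within the scatter), which is no step beyond the scatter. On that basis compound 4 is expected to give about 30% in this assay, with a likely range from 15% to 45%.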

Compound 4, a percentage reported as inhibition, in the whole organism at one dose (the size of the read-out at that dose, not a potency): 29.5%
Compound 4: middle estimate off by 0.5 percentage points, on the high side, within the range that was stated.
By their numbers in this assay, from the lowest: compound 2; then compounds 3, 1 and 4 (each within the scatter of the next).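

In this assay, among the compounds shown here, 4-fluorophenyl in place of butyl on a nitrogen on an aromatic ring gives the first single-place step, and it reads a number 2.2 percentage points higher from compound 3 to compound 4 (within the scatter). This position therefore carries either a butyl chain or a 4-fluorophenyl group with no step beyond the scatter, so the two groups cannot be told apart in this read-out at this one dose. The size and ring content of the group on this nitrogen change in this step, yet no measurement at hand bears on why the two compounds read alike.

The compounds shown leave open what the fluorine contributes, as compound 4 has no partner with unsubstituted phenyl on this nitrogen, and whether benzyl, cyclohexyl, a longer chain or a phenyl bearing a carboxylic acid would give a step beyond the scatter. Also open, from the compounds shown here alone, is whether this step would keep its size at other doses or at other times in this assay, as one dose and one time give the size of the read-out and not a potency.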